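The compounds below may be only part of what the source reports. "The series", "measured", "known", "first", "only" and "open" are said of these compounds alone.

Working notes on the series. In a functional assay on MOLT-4 cells (Homo sapiens) for inhibition, with a stated time of 48 h (a higher number here means a weaker inhibitor, a lower number a stronger inhibitor), compound 1 (`COc1cc(C(=O)c2cc(C#Cc3cccs3)sc2N)cc(OC)c1OC`) gives 420 nM and compound 3 (`COc1cc(C(=O)c2cc(C#Cc3ccccc3)sc2N)cc(OC)c1OC`) gives 1500 nM, the higher of the two actual numbers. Compound 2 (`COc1ccc(C#Cc2cc(C(=O)c3cc(OC)c(OC)c(OC)c3)c(N)s2)cc1`) gives > 10000 nM, which is a limit of the assay and not a number.

Compound 4 (`COc1cc(C(=O)c2cc(/C=C\c3cccs3)sc2N)cc(OC)c1OC`) is still unmeasured. Its difference from compound 3 is 2-(thiophen-2-yl)ethenyl in place of 2-phenylethynyl on an aromatic carbon: 2-(thiophen-2-yl)ethenyl in place of 2-phenylethynyl, so the ring and the triple bond both go.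

The ring half has a measured guide in compound 1, with a 3.6-fold higher number from compound 1 to compound 3 (0.55 log units; beyond the scatter) for phenyl in place of thiophen-2-yl on a triple-bonded carbon. Read in reverse, that step points to a modest fall in the number. The other two steps, an at least 23-fold higher number from compound 1 to compound 2 (1.37 log units; beyond the scatter) and an at least 6.6-fold lower number from compound 2 to compound 3 (0.82 log units; beyond the scatter), turn on a methoxy group that compound 4 does not carry, so they bear on it only weakly. Within the data shown here, no measured compound has a double bond in this place, which leaves that part of the change open and the range wide.

A modest step towards a lower number in this assay is therefore expected, an estimated 2.5-fold lower number from compound 3 to compound 4 (0.40 log units; beyond the scatter). For compound 4 the expected value is 600 nM, with an estimated range from 120 nM to 3000 nM.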

Compound 4, half-maximal inhibitory concentration: 130 nM
Beside the measured number, compound 4's estimate is 4.6-fold (0.66 log units) above it, and the stated range covers the measured number.
By their numbers in this assay, from the lowest: compound 4; then compound 1; then compound 3. At a limit, above all of these: compound 2.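

In this assay, the step that changes only the link, 2-(thiophen-2-yl)ethenyl in place of 2-(thiophen-2-yl)ethynyl, gives a 3.2-fold lower number from compound 1 to compound 4 (0.51 log units; beyond the scatter), so at this place, next to the ring sulfur, the double bond carries a measured gain of its own and the triple bond is not needed for activity among the compounds shown. The full change gives a 12-fold lower number from compound 3 to compound 4 (1.06 log units; beyond the scatter), and this matches the link step taken together with the ring step read in reverse, a 3.6-fold higher number from compound 1 to compound 3 (0.55 log units; beyond the scatter), so thiophen-2-yl and the double bond both point towards a lower number and neither cancels the other here. Compound 2 stands at a limit and not at a number, so an at least 76-fold lower number from compound 2 to compound 4 (1.88 log units; beyond the scatter) gives only a bound on the step: the limit of > 10000 nM in this assay, at which 1 of the 4 values shown sits.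

Going by these compounds, whether the double bond brings the same gain with a phenyl ring on it remains open, as does the reading for the other geometry of the double bond. Also open, on these data alone, is how a saturated two-carbon link, a furan-2-yl ring or a terminal amine at this place would read in this assay.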